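The source may report more compounds than this note shows. Statements on the series, on what has been measured and on what is new or still open speak of the compounds shown alone.

Measured in a physicochemical assay for solubility; on this read-out higher numbers stand for higher solubility and lower numbers for lower solubility:
- compound 1 `Cc1ccc(-c2cc(C(F)(F)F)ccc2[C@H]2CCOc3cc(S(=O)(=O)Nc4ccncn4)ccc32)cn1` gives 181000 nM
- compound 2 `O=S(=O)(Nc1nccs1)c1ccc2c(c1)OCC[C@@H]2c1ccc(C(F)(F)F)cc1-c1ccc(F)cn1` gives 7000 nM
- compound 3 `O=S(=O)(Nc1nccs1)c1ccc2c(c1)OCC[C@@H]2c1ccc(C(F)(F)F)cc1N1CCNCC1` gives 288000 nM

Compound 2 has the lowest number of the three. Compound 4 `O=S(=O)(Nc1ccncn1)c1ccc2c(c1)OCC[C@@H]2c1ccc(C(F)(F)F)cc1-c1ccc(F)cn1` differs from it in one place: pyrimidin-4-yl in place of 1,3-thiazol-2-yl on a sulfonamide nitrogen. This puts pyrimidin-4-yl in place of 1,3-thiazol-2-yl on a sulfonamide nitrogen.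

For the measured compounds named here, no measured step covers this change. Going by the values given here, the only measured step, a 41-fold higher number from compound 2 to compound 3 (1.61 log units; beyond the scatter), lies elsewhere on the molecule and shows only that large moves occur. Compound 1 carries pyrimidin-4-yl and gives 181000 nM, against compound 2 at 7000 nM, but these two also differ in a second place. A rise beyond the scatter is therefore expected in this assay, smaller than that gap. The estimated step is a 5.7-fold higher number from compound 2 to compound 4 (0.76 log units; beyond the scatter). For compound 4 the expected value is 40000 nM, with an estimated range of 12000 nM to 130000 nM.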

Compound 4, solubility: 181000 nM
Compound 4: middle estimate off by 4.5-fold (0.66 log units), on the low side; the whole stated range lies below it.
By their numbers in this assay, from the lowest: compound 2; then compounds 1, 4 and 3 (each within the scatter of the next).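

In this assay, pyrimidin-4-yl in place of 1,3-thiazol-2-yl on the sulfonamide nitrogen is a large step on its own (a 26-fold higher number from compound 2 to compound 4 (1.41 log units; beyond the scatter)). With pyrimidin-4-yl in that place, 5-fluoropyridin-2-yl and 6-methylpyridin-3-yl on the aromatic carbon are not told apart (no change at the digits printed from compound 1 to compound 4 (within the scatter)). Nothing at hand accounts for the size of the sulfonamide step.

Open, going by these compounds, is whether this step carries over to the piperazin-1-yl series, where compound 3 has 1,3-thiazol-2-yl on the sulfonamide nitrogen. Also open, on these data alone, is how a 1,3-oxazol-2-yl or pyridin-2-yl group would read on that nitrogen.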